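The source may hold more compounds than are shown below. What is called first, only, known or untested is meant among the compounds shown, and "the series" means these compounds.

Measured compounds in this series:

- compound 1, `CCCN(CCC)c1nc(C(F)(F)F)ccc1CNC(=O)C(C)c1ccc(NS(C)(=O)=O)c(F)c1`: in a functional assay on CHO-K1 cells for antagonist activity at transient receptor potential cation channel subfamily V member 1 (Homo sapiens), read by FLIPR (a higher number here means a weaker inhibitor, a lower number a stronger inhibitor), compound 1 gives 0.2 nM
- compound 2, `CC(C(=O)NCc1ccc(C(F)(F)F)nc1N1CCC(C(=O)c2ccc(F)cc2)CC1)c1ccc(NS(C)(=O)=O)c(F)c1`: compound 2 gives 3.9 nM
- compound 3, `CC(C(=O)NCc1ccc(C(F)(F)F)nc1N1CCC(=O)CC1)c1ccc(NS(C)(=O)=O)c(F)c1`: compound 3 gives 91 nM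

Compound 3 stands at the highest number of the three, so it is the weakest inhibitor shown; compound 2 sits well below it and compound 1 lowest of all. Among the measured compounds shown here, the only single-point step available is a 460-fold higher number from compound 1 to compound 3 (2.66 log units; beyond the scatter), a large loss on exchanging the open-chain amine for the ring ketone.

Compound 4, `COC1CCN(c2nc(C(F)(F)F)ccc2CNC(=O)C(C)c2ccc(NS(C)(=O)=O)c(F)c2)CC1`, differs from compound 3 by 4-methoxypiperidin-1-yl in place of 4-oxopiperidin-1-yl on an aromatic carbon. For the measured compounds named here, no measured pair isolates this exchange. What the values do show is that compound 2, which also carries a piperidine on that aromatic carbon but without the ring ketone, gives a much lower number than compound 3, while compound 1 without any ring gives the lowest. Taken together with the large step from compound 1 to compound 3, the removal of the ring ketone is expected to bring the number down, by a step of a 6.1-fold lower number from compound 3 to compound 4 (0.78 log units; beyond the scatter), though the size remains uncertain.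

Compound 4 is therefore estimated at 15 nM in this assay, with a likely range of 3 nM to 70 nM.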

Compound 4, inhibition constant: 2.4 nM
The estimate for compound 4 lay 6.3-fold (0.80 log units) above the measured number; the whole stated range lies above it.
By their numbers in this assay, from the lowest: compound 1; then compounds 4 and 2 (each within the scatter of the next); then compound 3.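

In this assay, the step of a 38-fold lower number from compound 3 to compound 4 (1.58 log units; beyond the scatter) with 4-methoxypiperidin-1-yl in place of 4-oxopiperidin-1-yl shows that a six-membered ring on this aromatic carbon need not carry the large penalty suggested by compound 3. The ring still does not match the open chain, with a 12-fold higher number from compound 1 to compound 4 (1.08 log units; beyond the scatter) on exchanging dipropylamino for 4-methoxypiperidin-1-yl. On the saturated ring carbon, the step of a 1.6-fold lower number from compound 2 to compound 4 (0.21 log units; within the scatter) for methoxy in place of (4-fluorophenyl)carbonyl shows that these two groups are not separated in this series.

No supporting measurement accounts for any of these steps. Going by these compounds, whether a hydroxy group, an amine or a carboxylic acid on that saturated ring carbon would keep the number near that of compound 4 remains open, as does whether a diethylamino group would match dipropylamino on the aromatic carbon.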